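Pyrimidine swap on an amine nitrogen: cytotoxicity notes

The compounds below may be only part of what the source reports. "The series", "measured", "known", "first", "only" and "open" are said of these compounds alone.

Of the compounds shown here, three define the series so far: compound 1 `C[C@@H](Cn1ccc(-c2ccc(C#N)c(Cl)c2)n1)NC(=O)c1ccccc1F`, compound 2 `C[C@@H](Cn1ccc(-c2ccc(C#N)c(Cl)c2)n1)Nc1ccccn1` and compound 3 `C[C@@H](Cn1ccc(-c2ccc(C#N)c(Cl)c2)n1)Nc1cncnc1`. In an ADME assay on L02 cells (Homo sapiens) for cytotoxicity, read by CCK-8 assay, with a stated time of 6 days (a lower number here means a stronger inhibitor, a higher number a weaker inhibitor), compound 1 gives "not determined" (no result reported). The same holds for compound 2, which gives "not determined" (no result reported). Compound 3 gives > 30000 nM, which is a limit of the assay and not a number. Going by the values given here, the position of compound 3 is thus (the limit of > 30000 nM in this assay, at which 1 of the 3 values shown sits), and no step between measured compounds is available.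

The next compound, compound 4 `Cc1ccnc(N[C@@H](C)Cn2ccc(-c3ccc(C#N)c(Cl)c3)n2)n1`, differs from compound 3 by 4-methylpyrimidin-2-yl in place of pyrimidin-5-yl on an amine nitrogen. Among the compounds with values here, no step beyond the scatter is expected in this assay, the only anchor being compound 3 with its limit of > 30000 nM. The estimated change is a number no higher from compound 3 to compound 4 (the limit leaves the size open), and a result reported only as a limit is the expected outcome. For compound 4 the expected value is 30000 nM, with an estimated range of 12000 nM to 60000 nM.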

Compound 4, half-maximal inhibitory concentration: > 30000 nM
Compound 4 was reported as a limit; the forecaster's own chance of this, stated with the estimate: 70%; the middle value lies on the limit itself.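

In this assay compound 3 and compound 4 are both reported only as limits of the assay, so no step can be read between them: the limit of > 30000 nM in this assay, at which 2 of the 4 values shown sit.

The compounds shown leave open whether any member of the series gives a true number in this assay.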